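Replacing a Three-Carbon Phenyl Tail with a Naphthyl Group

This account rests on a few compounds, and the source may have more. Where it says the series, first, only, none or still open, it means among the compounds named here.

Three compounds share one core and differ only in the group on a saturated chain carbon, three bonds along the chain from an oxygen on a saturated carbon. Compound 1 `CCC(CC)(c1ccc(OCC(O)C(C)(C)Cc2ccccc2)c(C)c1)c1ccc(OC[C@@H](O)CO)c(C)c1` gives 11000 nM in an assay on HL-60 cells for activation of vitamin D3 receptor (Homo sapiens); a lower number here means that less compound is needed, a higher number that more compound is needed for the effect. Compound 2 `CCC(CC)(c1ccc(OCC(O)C(C)(C)CCCc2ccccc2)c(C)c1)c1ccc(OC[C@@H](O)CO)c(C)c1` gives 3600 nM, which is a 3.1-fold lower number from compound 1 to compound 2 (0.49 log units; beyond the scatter). For compound 3 `CCC(CC)(c1ccc(OCC(O)C(C)(C)CCCCc2ccccc2)c(C)c1)c1ccc(OC[C@@H](O)CO)c(C)c1` only a limit is known, > 30000 nM, the limit described by the limit of > 30000 nM in this assay, at which 1 of the 3 values shown sits. Compared with its neighbours this means an at least 2.7-fold higher number from compound 1 to compound 3 (0.43 log units; beyond the scatter) and an at least 8.3-fold higher number from compound 2 to compound 3 (0.92 log units; beyond the scatter). Compound 4 `CCC(CC)(c1ccc(OCC(O)C(C)(C)Cc2ccc3ccccc3c2)c(C)c1)c1ccc(OC[C@@H](O)CO)c(C)c1` carries naphthalen-2-yl in place of 3-phenylpropyl on a saturated chain carbon, three bonds along the chain from an oxygen on a saturated carbon; the aromatic group again sits directly on the chain, as in compound 1. Since the directly attached phenyl of compound 1 gave a measurable number while the longest tail gave only a limit, a lower number is expected for compound 4, an expected step of an at least 3.3-fold lower number from compound 3 to compound 4 (0.52 log units; beyond the scatter). Compound 4 is therefore estimated at 9000 nM, between 2500 nM and 30000 nM.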

Compound 4, half-maximal effective concentration: > 30000 nM
Compound 4: a limit, no number; the forecaster's own chance of this, stated with the estimate: 25%; at least 3.3-fold (0.52 log units) between middle value and limit.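

In this assay compound 4, like compound 3, gives only a limit and not a number: the limit of > 30000 nM in this assay, at which 2 of the 4 values shown sit.

With naphthalen-2-yl on this chain carbon, the result is an at least 2.7-fold higher number from compound 1 to compound 4 (0.43 log units; beyond the scatter) and an at least 8.3-fold higher number from compound 2 to compound 4 (0.92 log units; beyond the scatter), so this two-ring group does not retain the measurable values of the shorter phenyl tails. The step between compound 3 and compound 4 cannot be read, as both are limits.

From the compounds shown here alone, how far compound 3 and compound 4 lie past that limit stays open. So does whether a naphthalen-1-yl or cyclohexyl group at this position would give a measurable value in this assay.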